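The source may report more compounds than this note shows. Statements on the series, on what has been measured and on what is new or still open speak of the compounds shown alone.

Measured in a functional assay on MGC-803 cells (Homo sapiens) for cytotoxicity, read by MTT assay, with a stated time of 72 h; a higher number here means a weaker inhibitor, a lower number a stronger inhibitor:
- compound 1 `CC(C)=C1C(=O)N(c2ccc(Cl)cc2)N(c2ccc(Cl)cc2)C1=O`: 39000 nM
- compound 2 `CCC(C)=C1C(=O)N(c2ccc(Cl)cc2)N(c2ccc(Cl)cc2)C1=O`: 66500 nM
- compound 3 `O=C1C(=Cc2ccc(Cl)cc2)C(=O)N(c2ccc(Cl)cc2)N1c1ccc(Cl)cc1`: 32600 nM

Compound 3 lies within the scatter of compound 1 and beyond the scatter of compound 2. The next structure, compound 4 `COc1cccc(C=C2C(=O)N(c3ccc(Cl)cc3)N(c3ccc(Cl)cc3)C2=O)c1O`, carries this change: 2-hydroxy-3-methoxyphenyl in place of 4-chlorophenyl on a double-bonded chain carbon bound to a double-bonded ring carbon, on a double-bonded chain carbon bound to a double-bonded ring carbon. Among the compounds with values here, the one measured step, a 1.7-fold higher number from compound 1 to compound 2 (0.23 log units; within the scatter), is small and concerns a different change, so it bears only loosely. Within the data shown here, no measured step replaces this aromatic group, so the direction is uncertain and no shift beyond the scatter is expected. The expected step is a 1.5-fold lower number from compound 3 to compound 4 (0.17 log units; within the scatter). For compound 4 the estimated value is 22000 nM, with an expected range from 7000 nM to 65000 nM.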

Compound 4, half-maximal inhibitory concentration: 24300 nM
Compound 4: middle estimate off by 1.1-fold (0.04 log units), on the low side; measured number inside the range.
By their numbers in this assay, from the lowest: compounds 4, 3, 1 and 2 (each within the scatter of the next, the first and the last beyond it).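

In this assay, 2-hydroxy-3-methoxyphenyl in place of 4-chlorophenyl on a double-bonded chain carbon bound to a double-bonded ring carbon gives a 1.3-fold lower number from compound 3 to compound 4 (0.13 log units; within the scatter) and so leaves the number within the usual scatter. Within the data shown here, this is the first measured change of the aromatic group at this position, and it shows that a hydroxy and a methoxy group can replace the chlorine without a clear loss or gain. Going by these compounds, whether an amine or a carboxylic acid on this ring would move the number beyond the scatter stays open, as does the separate contribution of the hydroxy and the methoxy group. No measurement shown here offers an explanation for this result.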